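Swapping Chloro for Methyl on the Phenyl Ring

A few compounds are considered here, and "the series" means these few. Any claim that something is new, unique, unknown or untested is made for them only; others in the source may bear on it.

Measured so far:
compound 1, `CC(C)(CCCCOc1cc(-c2ccccc2)c2ccccc2n1)C(=O)O` — 183 nM
compound 2, `CC(C)(CCCCOc1cc(-c2ccc(C(F)(F)F)cc2)c2ccccc2n1)C(=O)O` — 300 nM
compound 3, `CC(C)(CCCCOc1cc(-c2ccc(Cl)cc2)c2ccccc2n1)C(=O)O` — 15 nM

In an assay on membranes from spleen (Cavia porcellus) for binding affinity to leukotriene B4 receptor 1 (Homo sapiens) (a higher number here means a weaker inhibitor, a lower number a stronger inhibitor), compound 3 has the lowest number of the three, and both steps to it lie beyond the scatter: a 12-fold lower number from compound 1 to compound 3 (1.09 log units; beyond the scatter) and a 20-fold lower number from compound 2 to compound 3 (1.30 log units; beyond the scatter). Compound 4, `Cc1ccc(-c2cc(OCCCCC(C)(C)C(=O)O)nc3ccccc23)cc1`, differs from compound 3 by methyl in place of chloro on an aromatic carbon. Among the compounds with values here, no measured step changes chloro to methyl, so the expectation rests only on the two steps into compound 3, which show that replacing chloro at this position with hydrogen or with trifluoromethyl raised the number strongly. A moderate rise is therefore expected for compound 4, though with wide uncertainty. Compound 4 is estimated at 60 nM, in a range from 15 nM to 250 nM. This amounts to an expected step of a 4.0-fold higher number from compound 3 to compound 4 (0.60 log units; beyond the scatter).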

Compound 4, half-maximal inhibitory concentration: 30 nM
The estimate for compound 4 lay 2.0-fold (0.30 log units) above the measured number, within the range that was stated.
By their numbers in this assay, from the lowest: compounds 3 and 4 (each within the scatter of the next); then compounds 1 and 2 (each within the scatter of the next).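

In this assay, 4-methylphenyl cannot be told apart from 4-chlorophenyl (a 2.0-fold higher number from compound 3 to compound 4 (0.30 log units; within the scatter)), so the low number at this position does not depend on chloro alone. Within the data shown here, the methyl group also keeps the clear advantage over hydrogen (a 6.1-fold lower number from compound 1 to compound 4 (0.79 log units; beyond the scatter)) and over trifluoromethyl (a 10-fold lower number from compound 2 to compound 4 (1.00 log units; beyond the scatter)), which leaves trifluoromethyl as the one group of the three substituents here that brings no such drop. No measurement shown explains why methyl and chloro match while trifluoromethyl does not. Still open, from the compounds shown here alone, is how a fluoro, methoxy or amine group would compare in this same place.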